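A few compounds are considered here, and "the series" means these few. Any claim that something is new, unique, unknown or untested is made for them only; others in the source may bear on it.

Compound 1 `Cc1ccc(CC(Oc2ccc(C(C)C)cc2)C(=O)O)cc1`: < 50 mg/kg (a limit)
Compound 2 `Cc1ccc(CC(C)(Oc2ccc(C(C)C)cc2)C(=O)O)cc1`: < 1 mg/kg (a limit)
Compound 3 `CCc1cccc(CC(C)(Oc2ccc(C(C)C)cc2)C(=O)O)c1`: 0.5 mg/kg

All three values come from a functional assay on the whole organism for inhibition, with Rattus norvegicus as the target; a lower number here means that less compound is needed, a higher number that more compound is needed for the effect. Compound 2 has no exact number on this read-out: its < 1 mg/kg is a limit.

Compound 4 `CC(C)c1ccc(OC(C)(Cc2ccc(-c3ccccc3)cc2)C(=O)O)cc1` keeps the core of compound 2 and differs from it as follows: phenyl in place of methyl on an aromatic carbon. In words, this is phenyl in place of methyl on an aromatic carbon, para to a large group.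

Two measured steps are available. The one that bears most closely is a step that the limit leaves unreadable from compound 2 to compound 3, since it also changes the ring that carries methyl, here 3-ethylphenyl in place of 4-methylphenyl. The other, a step that the two limits leave unreadable from compound 1 to compound 2, is a methyl in place of hydrogen on a saturated chain carbon, so it lies elsewhere in the molecule and says little about this change. Neither step has a readable size, so neither sets a direction. Compound 3 gives 0.5 mg/kg after its change to that ring, so a large loss in this assay is not expected, though the larger group leaves the outcome open. The expected change is a step that the limit leaves unreadable from compound 2 to compound 4. For compound 4 the estimate is 0.8 mg/kg, with an expected range from 0.2 mg/kg to 5 mg/kg.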

Compound 4, dose for half-maximal effect: 1 mg/kg
The estimate for compound 4 lay 1.3-fold (0.10 log units) below the measured number; measured number inside the range.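

In this assay, among the compounds shown here, compound 4 gives the first exact number for a group on this aromatic carbon, para to a large group, at 1 mg/kg. Compound 4 thus shows that phenyl, with its six carbon atoms and its own six-membered aromatic ring, can stand where a single methyl carbon stood and still give a readable dose in the whole animal, and the change is a number no lower from compound 2 to compound 4 (the limit leaves the size open). Neither the size of this step nor that of the earlier steps can be read because each one involves the limit of compound 2: the limit of < 1 mg/kg in this assay, at which 1 of the 4 values shown sits.

The compounds shown leave open how far the result depends on the carbon-only aromatic ring, since a pyridyl, a phenoxy or a benzyl group on this aromatic carbon does not appear among them. They also leave open whether a phenyl carrying a chlorine or a methoxy group of its own would give a dose close to that of compound 4, and how a shorter group such as ethyl would read at this place.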